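The source may report more compounds than this note shows. Statements on the series, on what has been measured and on what is new or still open speak of the compounds shown alone.

The study concerns a shared core carrying a 4-methoxyphenyl group, as seen in compound 1 `COc1ccc(-c2cc(=O)c3c(OC)cc(OC)cc3[nH]2)cc1`. In a functional assay on SUP-B15 cells (Homo sapiens) for antiproliferative activity, with a stated time of 72 h (on this read-out lower numbers stand for an effect already at smaller amounts and higher numbers for an effect only at larger amounts of compound), compound 1 gives > 62000 nM, which is a limit of the assay. Two further compounds carry a sulfonyl group on the aromatic nitrogen of that core. Compound 2 `COc1ccc(-c2cc(=O)c3c(OC)cc(OC)cc3n2S(=O)(=O)c2cccc([N+](=O)[O-])c2)cc1` gives > 39600 nM in this assay, again a limit. Compound 3 `COc1ccc(-c2cc(=O)c3c(OC)cc(OC)cc3n2S(=O)(=O)c2ccc(C)c([N+](=O)[O-])c2)cc1` gives > 51700 nM in this assay, also a limit. Going by the values given here, the one measured step, a step that the two limits leave unreadable from compound 2 to compound 3, therefore cannot be read, since all three values shown sit at limits: the limit of > 39600 nM in this assay, at which 1 of the 3 values shown sits, the limit of > 51700 nM in this assay, at which 1 of the 3 values shown sits, and (the limit of > 62000 nM in this assay, at which 1 of the 3 values shown sits). Compound 4 `COc1ccc(-c2cc(=O)c3c(OC)cc(OC)cc3n2S(=O)(=O)c2ccc(Cl)cc2)cc1` differs from compound 1 by (4-chlorophenyl)sulfonyl in place of hydrogen on an aromatic nitrogen. Among the compounds with values here, no measured step bears directly on this change, and the two sulfonyl-bearing compounds 2 and 3 show nothing but limits, so no step in this assay beyond the scatter is expected, and compound 4 is most likely to return a limit as well. The estimate for compound 4 is accordingly 60000 nM, with a range from 20000 nM to 150000 nM. That would mean an expected step of an at least 1.0-fold lower number from compound 1 to compound 4 (0.01 log units; that floor lies within the scatter).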

Compound 4, half-maximal effective concentration: > 34400 nM
Compound 4: no number, only a limit (the forecaster's own chance of this, stated with the estimate: 85%); the middle value lies beyond the limit too.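

In this assay compound 4 gives > 34400 nM, which is a limit of the assay, and the steps joining compound 4 to compound 1, compound 2 and compound 3 cannot be read. The compounds shown leave open whether any sulfonyl group on the aromatic nitrogen changes the result in this assay.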